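The source may hold more compounds than are shown below. What is called first, only, known or untested is meant among the compounds shown, and "the series" means these compounds.

Three compounds have been measured in an assay on HEK293 cells for displacement of a labelled ligand from 5-hydroxytryptamine receptor 6 (Homo sapiens); on this read-out lower numbers stand for stronger inhibition and higher numbers for weaker inhibition:

Compound 1, `CN1CCN(c2ccc([N+](=O)[O-])c(Nn3cccc3)c2)CC1`, gives 481 nM.
Compound 2, `CC(Nc1cc(N2CCN(C)CC2)ccc1[N+](=O)[O-])c1ccccc1`, gives 12 nM.
Compound 3, `CN1CCN(c2ccc([N+](=O)[O-])c(NCc3ccc(F)cc3)c2)CC1`, gives 172 nM.

Compound 2 holds the lowest number of the three in this assay. Its steps to both neighbours lie beyond the scatter: a 14-fold higher number from compound 2 to compound 3 (1.16 log units; beyond the scatter), and a 40-fold lower number from compound 1 to compound 2 (1.60 log units; beyond the scatter). The step of a 2.8-fold lower number from compound 1 to compound 3 (0.45 log units; beyond the scatter) is the smaller of the measured ones.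

Compound 4, `CN1CCN(c2ccc([N+](=O)[O-])c(NC(c3ccccc3)c3ccccc3)c2)CC1`, has not yet been measured. It differs from compound 2 in one place: phenyl in place of methyl on a saturated chain carbon bound to an aromatic carbon and a nitrogen on an aromatic ring. Within the data shown here, no measured step touches that saturated chain carbon directly; the measured steps all exchange the whole group on the nitrogen on the aromatic ring. They show that what sits on that nitrogen moves this assay strongly, with compound 2 well ahead of compound 3 and compound 1. Because the step of a 14-fold higher number from compound 2 to compound 3 (1.16 log units; beyond the scatter) is large, the saturated carbon in compound 2 appears to carry weight, so a change there is expected to matter. The estimate for compound 4 is a modest rise from compound 2, a 2.5-fold higher number from compound 2 to compound 4 (0.40 log units; beyond the scatter), with wide uncertainty. Compound 4 is expected to give about 30 nM in this assay, between 8 nM and 120 nM.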

Compound 4, inhibition constant: 4490 nM
Estimate against measurement, compound 4: 150-fold (2.18 log units) below; the measured number lies above the stated range.
By their numbers in this assay, from the lowest: compound 2; then compound 3; then compound 1; then compound 4.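

In this assay, phenyl in place of methyl on the saturated chain carbon bound to an aromatic carbon and a nitrogen on an aromatic ring gives a 370-fold higher number from compound 2 to compound 4 (2.57 log units; beyond the scatter) and is the largest step recorded in this set. Among these compounds, the earlier steps exchanged the whole group on the nitrogen, so they could not separate this carbon from the rest of that group, whereas this change leaves everything else in compound 2 in place and shows that the single methyl-to-phenyl exchange alone can take the number from the lowest of the series to the highest, past compound 1. No measured evidence on the reason for this rise is available here.

From the compounds shown here alone, it remains open whether the rise belongs to phenyl itself or would also appear with an ethyl, an isopropyl or a cyclopropyl on that carbon. The compounds shown also leave unsettled whether a hydroxymethyl or an aminomethyl there would keep the number near that of compound 2.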